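Following the step from compound 1 to compound 3

The source may report more compounds than this note shows. Statements on the series, on what has been measured and on what is new or still open speak of the compounds shown alone.

compound 1 `CN1C/C(=C\c2cccc([N+](=O)[O-])c2)C(=O)/C(=C/c2ccccc2F)C1` gives 1010 nM
compound 2 `COc1cc(/C=C2\CN(C)C/C(=C\c3ccc(Cl)c(Cl)c3)C2=O)cc(OC)c1` gives 3260 nM

In a functional assay on THP-1 cells (Homo sapiens) for cytotoxicity, read by MTT assay, with a stated time of 24 h (on this read-out lower numbers stand for stronger inhibition and higher numbers for weaker inhibition), compound 1 stands at 1010 nM as the lower of the two numbers, while compound 2 at 3260 nM lies higher, beyond the usual scatter. Compound 3 `CN1C/C(=C\c2ccc(Br)cc2)C(=O)/C(=C/c2cccc([N+](=O)[O-])c2)C1` has not yet been measured. Its difference from compound 1 is 4-bromophenyl in place of 2-fluorophenyl on a double-bonded chain carbon bound to a double-bonded ring carbon with 4-bromophenyl in place of 2-fluorophenyl on a double-bonded chain carbon bound to a double-bonded ring carbon. For the measured compounds named here, compound 1 and compound 2 differ in more than one place, so no measured step shows what this swap does. Without such a guide, no step beyond the scatter is expected in this assay in either direction. The estimated step is a 1.3-fold higher number from compound 1 to compound 3 (0.11 log units; within the scatter) at this stage. For compound 3 the expected value is 1300 nM with 400 nM to 4000 nM as the estimated range.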

Compound 3, half-maximal inhibitory concentration: 7690 nM
The estimate for compound 3 lay 5.9-fold (0.77 log units) below the measured number; the whole stated range lies below it.
By their numbers in this assay, from the lowest: compound 1; then compound 2; then compound 3.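

In this assay, putting 4-bromophenyl in place of 2-fluorophenyl on a double-bonded chain carbon bound to a double-bonded ring carbon gives a 7.6-fold higher number from compound 1 to compound 3 (0.88 log units; beyond the scatter) and so lies beyond the scatter. For the compounds shown here, this is the first measured sign that the group at this position matters for the read-out, even though both groups have the same heavy-atom count, a single aromatic ring of carbon and no hydrogen-bond donors or acceptors. No measurement at hand explains why the number rises.

The swap changes both the halogen and the number in the group's name, and these two compounds cannot separate those changes. On these data alone, whether an unsubstituted phenyl, or a phenyl carrying an amine or a carboxylic acid, would stay close to compound 1 also remains open.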